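Moving a Nitrile on the Cyanophenyl Group

The source may report more compounds than this note shows. Statements on the series, on what has been measured and on what is new or still open speak of the compounds shown alone.

Compound 1 `CCN(CC)CCCOc1cc2ncnc(Nc3ccc(C#N)cc3)c2cc1OC`: 59400 nM
Compound 2 `COc1cc2c(Nc3ccc(C#N)cc3)ncnc2cc1OCCCN1CCC(N2CCCCC2)CC1`: 8840 nM
Compound 3 `CCN1CCN(CCCOc2cc3ncnc(Nc4ccc(C#N)cc4)c3cc2OC)CC1`: 9580 nM

These values come from a functional assay on HepG2 cells (Homo sapiens) for antiproliferative activity, read by MTT assay, with a stated time of 72 h; a lower number here means a stronger inhibitor, a higher number a weaker inhibitor. There, compound 3 cannot be told apart from compound 2, since the gap between them is small: a 1.1-fold higher number from compound 2 to compound 3 (0.03 log units; within the scatter). The gap to the remaining value is clearly larger: a 6.2-fold lower number from compound 1 to compound 3 (0.79 log units; beyond the scatter).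

The next compound is compound 4 `CCN1CCN(CCCOc2cc3ncnc(Nc4cccc(C#N)c4)c3cc2OC)CC1`. It has the same atoms as compound 3, joined differently: 3-cyanophenyl in place of 4-cyanophenyl on a nitrogen on an aromatic ring. Put simply, 3-cyanophenyl stands in place of 4-cyanophenyl on a nitrogen on an aromatic ring, while the 4-ethylpiperazin-1-yl group stays.

Among the measured compounds shown here, no measured step touches this part of the molecule. All three steps swap the amine at the end of the chain, so they bear on the question only indirectly. The two beyond the scatter, a 6.7-fold lower number from compound 1 to compound 2 (0.83 log units; beyond the scatter) and a 6.2-fold lower number from compound 1 to compound 3 (0.79 log units; beyond the scatter), give a rough idea of how far one change has moved a value in this assay. They say nothing about direction here, so no clear shift is expected, and a step of that modest size either way would be no surprise. The expected change is a 1.1-fold lower number from compound 3 to compound 4 (0.03 log units; within the scatter). Compound 4 is expected to give about 9000 nM, with an estimated range from 3000 nM to 28000 nM.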

Compound 4, half-maximal inhibitory concentration: 13700 nM
For compound 4 the middle estimate is 1.5-fold (0.18 log units) below the measured one; the measured number falls inside the stated range.
By their numbers in this assay, from the lowest: compounds 2, 3 and 4 (each within the scatter of the next); then compound 1.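

In this assay, this is the only step shown that touches the cyanophenyl group rather than the amine at the end of the chain, and it gives a 1.4-fold higher number from compound 3 to compound 4 (0.16 log units; within the scatter). Both groups hold the same atoms and the same counted features, so the only difference is where the nitrile sits on the ring, and that difference cannot be told from the usual scatter of repeated measurements, whereas replacing diethylamino with 4-ethylpiperazin-1-yl gave a clear step, a 6.2-fold lower number from compound 1 to compound 3 (0.79 log units; beyond the scatter). Nothing available explains why moving the nitrile leaves the number within the scatter.

As far as these compounds go, the move from 4-cyanophenyl to 3-cyanophenyl has been read only with the 4-ethylpiperazin-1-yl group in place, so it remains open whether the same move would also stay within the scatter with diethylamino or 4-(piperidin-1-yl)piperidin-1-yl at the end of the chain. From the compounds shown here alone, it also remains open what would happen if the nitrile itself gave way to another group on that ring, such as a carboxylic acid or an amide, since these compounds vary only its place and not its identity.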